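Swapping Amino for Trifluoromethyl on Compound 1

This account rests on a few compounds, and the source may have more. Where it says the series, first, only, none or still open, it means among the compounds named here.

Compound 1 `CC(/C=N/Nc1ccc([N+](=O)[O-])cc1)=N\NC(=O)c1ccc(N)cc1` gives 75000 nM in an ADME assay on J774 cells (Mus musculus, strain BALB/c) for cytotoxicity, read by resazurin assay, with a stated time of 72 h (a higher number here means that more compound is tolerated, a lower number that less compound is tolerated), and stands highest of the two plain numbers in this set; compound 3 `CC(/C=N/Nc1ccc([N+](=O)[O-])cc1)=N\NC(=O)c1ccccc1N` gives 29800 nM, with a 2.5-fold lower number from compound 1 to compound 3 (0.40 log units; beyond the scatter). Compound 2 `CC(/C=N/Nc1ccc([N+](=O)[O-])cc1)=N\NC(=O)c1ccccc1C` gives > 100000 nM, which is a limit of the assay rather than a number. Compound 2 thus stands at the limit of > 100000 nM in this assay, at which 1 of the 3 values shown sits. Compound 4 `CC(/C=N/Nc1ccc([N+](=O)[O-])cc1)=N\NC(=O)c1ccc(C(F)(F)F)cc1` carries trifluoromethyl in place of amino on an aromatic carbon. For the measured compounds named here, the steps that bear on this exchange are an at least 1.3-fold higher number from compound 1 to compound 2 (0.12 log units; that floor lies within the scatter) and an at least 3.3-fold lower number from compound 2 to compound 3 (0.52 log units; beyond the scatter), where a methyl replaces an amino and the reverse; across compounds 1, 2 and 3, trading the amino for a group with no donors or acceptors tends to raise the number. Compound 4 is therefore expected to show a modest rise, a 1.3-fold higher number from compound 1 to compound 4 (0.12 log units; within the scatter), with an estimated value of 100000 nM and a range from 40000 nM to 250000 nM.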

Compound 4, half-maximal cytotoxic concentration: 78700 nM
Compound 4: the middle estimate sits 1.3-fold (0.10 log units) above what was measured; measured number inside the range.
By their numbers in this assay, from the lowest: compound 3; then compounds 1 and 4 (each within the scatter of the next). At a limit, above all of these: compound 2.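

In this assay the exchange at this position, para to a large group, changes nothing that can be told apart: a 1.0-fold higher number from compound 1 to compound 4 (0.02 log units; within the scatter). Trifluoromethyl carries no hydrogen-bond donor or acceptor, yet compound 4 does not part from compound 1, so the tendency seen across compounds 1, 2 and 3 does not extend to compound 4. Nothing shown gives a cause for this. On these data alone, whether a carboxylic acid, a nitrile or a longer chain at this same position would move the number away from that of compound 1 remains open.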